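The source may report more compounds than this note shows. Statements on the series, on what has been measured and on what is new or still open speak of the compounds shown alone.

Measured so far:
- compound 1, `COc1ccc(NC(=O)[C@H]2CN(C)C[C@@H]2c2ccc(/C=C/C(=O)Nc3ccccc3N)cc2)cc1`: 54 mL/min/kg
- compound 2, `CN1C[C@H](C(=O)Nc2ccc(C3CC3)cc2)[C@@H](c2ccc(/C=C/C(=O)Nc3ccccc3N)cc2)C1`: 60 mL/min/kg

Both values come from an in vitro ADME assay on microsomes from liver (Mus musculus) for pharmacokinetics, read by LC-MS, with a stated time of 10 min, tested at 1 uM; on this read-out higher numbers stand for fast clearance and lower numbers for slow clearance. Going by the values given here, compound 2 holds the higher of the two numbers; its nearest neighbour is compound 1, and the single step between them, a 1.1-fold higher number from compound 1 to compound 2 (0.05 log units; within the scatter), sits inside the scatter of repeated runs, so the two compounds cannot be told apart on this read-out.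

Compound 3, `Cc1cccc(NC(=O)[C@H]2CN(C)C[C@@H]2c2ccc(/C=C/C(=O)Nc3ccccc3N)cc2)c1`, has not yet been run. It differs from compound 2 in one place: 3-methylphenyl in place of 4-cyclopropylphenyl on an amide-type nitrogen. Among the compounds with values here, the only step that bears on it is the one from compound 1 to compound 2, which exchanged two groups on the same aromatic ring and moved the number by a 1.1-fold higher number from compound 1 to compound 2 (0.05 log units; within the scatter). No other exchange at this amide-type nitrogen has been measured.

On that basis compound 3 is expected to sit close to compound 2, with a 1.1-fold lower number from compound 2 to compound 3 (0.03 log units; within the scatter) as the estimated step, no larger than the scatter. The estimated clearance for compound 3 is 56 mL/min/kg, with a range of 30 mL/min/kg to 105 mL/min/kg.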

Compound 3, clearance: 74 mL/min/kg
Estimate against measurement, compound 3: 1.3-fold (0.12 log units) below, within the range that was stated.
By their numbers in this assay, from the lowest: compounds 1, 2 and 3 (each within the scatter of the next).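

In this assay, the exchange on the amide-type nitrogen gives a 1.2-fold higher number from compound 2 to compound 3 (0.09 log units; within the scatter) and a 1.4-fold higher number from compound 1 to compound 3 (0.14 log units; within the scatter), and both steps lie within the scatter. The earlier pair covered only 4-methoxyphenyl and 4-cyclopropylphenyl; with 3-methylphenyl added, a group carrying its substituent at a different numbered ring position also cannot be told apart from either of them on this read-out. No measurement is at hand that would explain these results.

On these data alone, all three groups at this position are substituted phenyl rings without a hydrogen-bond donor, so it remains open whether an amine or a carboxylic acid on that ring would give a clearance step beyond the scatter. As far as these compounds go, whether 4-methylphenyl would differ from 3-methylphenyl also remains open.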